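A few compounds are considered here, and "the series" means these few. Any claim that something is new, unique, unknown or untested is made for them only; others in the source may bear on it.

In a functional assay on SW-620 cells (Homo sapiens) for cytotoxicity, read by MTT assay, with a stated time of 72 h (on this read-out higher numbers stand for weaker inhibition and lower numbers for stronger inhibition), compound 1 (`COc1cccc(/C=C2\CCC/C(=C\c3cccc(O)c3)C2=O)c1OC`) gives 6400 nM and compound 2 (`COc1ccc(/C=C2\CCC/C(=C\c3ccc(Cl)cc3)C2=O)cc1OC`) gives 5900 nM while compound 3 (`COc1ccc(/C=C2\CCC/C(=C\c3cccc(O)c3)C2=O)cc1OC`) gives 1900 nM as the lowest of the three numbers. Compound 4 (`COc1cc(/C=C2\CCC/C(=C\c3ccc(OC)c(OC)c3)C2=O)ccc1O`) differs from compound 3 on a double-bonded chain carbon bound to a double-bonded ring carbon (4-hydroxy-3-methoxyphenyl in place of 3-hydroxyphenyl on a double-bonded chain carbon bound to a double-bonded ring carbon). For the measured compounds named here, the one measured step at this place is the exchange of 4-chlorophenyl for 3-hydroxyphenyl (a 3.1-fold lower number from compound 2 to compound 3 (0.49 log units; beyond the scatter)), which was modest but beyond the scatter. Going by the values given here, no measured step introduces 4-hydroxy-3-methoxyphenyl, so this guide is weak. In this assay a small rise is therefore expected, smaller than that step and perhaps within the scatter. The expected change runs as follows (a 1.3-fold higher number from compound 3 to compound 4 (0.12 log units; within the scatter)). Compound 4 is estimated at 2500 nM within an expected range (1000 nM to 6000 nM).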

Compound 4, half-maximal inhibitory concentration: 4500 nM
Beside the measured number, compound 4's estimate is 1.8-fold (0.26 log units) below it; the measured number falls inside the stated range.
By their numbers in this assay, from the lowest: compound 3; then compounds 4, 2 and 1 (each within the scatter of the next).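

In this assay, 4-hydroxy-3-methoxyphenyl on this double-bonded chain carbon does not hold the lower number that 3-hydroxyphenyl gives (a 2.4-fold higher number from compound 3 to compound 4 (0.37 log units; beyond the scatter)). Against 4-chlorophenyl, the same group makes no change that stands clear of the scatter (a 1.3-fold lower number from compound 2 to compound 4 (0.12 log units; within the scatter)), so carrying a hydroxy group is not enough on its own to match compound 3. No evidence at hand accounts for this difference between the two hydroxy-bearing groups.

The compounds shown leave open whether 4-hydroxyphenyl or 3-methoxyphenyl alone would keep the number of compound 3. They also leave open how an amine or a carboxylic acid would fare at this place.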